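The source may report more compounds than this note shows. Statements on the series, on what has been measured and on what is new or still open speak of the compounds shown alone.

Compound 1 `COc1cc2nc(N3CCN(S(=O)(=O)c4ccc(Cl)cc4)CC3)nc(N)c2cc1OC` in a functional assay on PC-3 cells (Homo sapiens) for inhibition (a higher number here means a weaker inhibitor, a lower number a stronger inhibitor), gives 23000 nM. Compound 2 `COc1cc2nc(N3CCN(S(=O)(=O)c4cccc([N+](=O)[O-])c4)CC3)nc(N)c2cc1OC` gives 32000 nM. Compound 3 `COc1cc2nc(N3CCN(S(=O)(=O)c4ccc(S(C)(=O)=O)cc4)CC3)nc(N)c2cc1OC` gives 17000 nM.

All three share the same core and differ only in the aromatic group attached to the sulfonyl sulfur. Compound 3 sits at the low end of the three numbers, but the differences are small: a 1.4-fold lower number from compound 1 to compound 3 (0.13 log units; within the scatter) and a 1.9-fold lower number from compound 2 to compound 3 (0.27 log units; within the scatter), both within the scatter, so the three compounds cannot be told apart. Likewise a 1.4-fold higher number from compound 1 to compound 2 (0.14 log units; within the scatter) is within the scatter.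

Compound 4 `COc1cc2nc(N3CCN(S(=O)(=O)c4cc(C(=O)O)c(Cl)cc4Cl)CC3)nc(N)c2cc1OC` has not yet been measured. It differs from compound 3 in one place: 5-carboxy-2,4-dichlorophenyl in place of 4-(methylsulfonyl)phenyl on a sulfonyl sulfur.

The three measured steps all bear on this change, since each of them also swaps one aromatic group for another on the same sulfonyl sulfur. None of them moved the number beyond the scatter, which gives no reason to expect a step of any size or direction here. The expectation is therefore that compound 4 stays close to compound 3 in this assay, with a 1.2-fold higher number from compound 3 to compound 4 (0.07 log units; within the scatter). Compound 4 is estimated at 20000 nM, with a likely range from 7000 nM to 60000 nM.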

Compound 4, half-maximal inhibitory concentration: 52000 nM
Estimate against measurement, compound 4: 2.6-fold (0.41 log units) below; low and high end bracket the measured number.
By their numbers in this assay, from the lowest: compounds 3, 1, 2 and 4 (each within the scatter of the next, the first and the last beyond it).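

Until now, no swap of the aromatic group on the sulfonyl sulfur had moved the number in this assay beyond the scatter, but 5-carboxy-2,4-dichlorophenyl does so in two comparisons: a 3.1-fold higher number from compound 3 to compound 4 (0.49 log units; beyond the scatter) and a 2.3-fold higher number from compound 1 to compound 4 (0.35 log units; beyond the scatter). This shows that the group at this position can shift the number, although both steps are modest and the third comparison, a 1.6-fold higher number from compound 2 to compound 4 (0.21 log units; within the scatter), does not separate the two compounds. No data on hand show which part of the entering group, the carboxy or the chloro substituents, accounts for these steps.

The entering group carries a carboxy group and two chloro groups together, so the compounds shown leave open what each contributes alone; a phenyl bearing only a carboxylic acid, or the same dichlorophenyl with a methyl ester or an amide in place of the acid, would help separate them. Also open, going by these compounds, is whether any group on this sulfonyl sulfur can bring the number clearly below those of compound 1 and compound 3, for instance an aminophenyl, an unsubstituted phenyl or a short alkyl chain.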